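The source may hold more compounds than are shown below. What is called first, only, known or untested is meant among the compounds shown, and "the series" means these compounds.

Two compounds built on one shared core, each carrying a long branched side chain, were tested in an ADME assay on BJ cells (Homo sapiens) for cytotoxicity, with a stated time of 72 h; on this read-out higher numbers stand for an effect only at larger amounts of compound and lower numbers for an effect already at smaller amounts. Compound 1 `CC(C)=CCC/C(C)=C/Cc1c(O)cc2c(c1O)C(=O)C[C@@H](c1cc(O)cc(O)c1)O2` gives 7500 nM. Compound 2 `C=C(C)C(O)CC/C(C)=C/Cc1c(O)cc2c(c1O)C(=O)C[C@@H](c1ccc(O)c(OC)c1)O2` reaches only the limit of the assay, reported as > 10000 nM, so no number is known for it. Going by the values given here, this places compound 2 at the limit of > 10000 nM in this assay, at which 1 of the 2 values shown sits, and the value of compound 1 stands as the only measured number in the set. Compound 3 `COc1cc([C@@H]2CC(=O)c3c(cc(O)c(C/C=C(\C)C/C=C/C(C)(C)O)c3O)O2)ccc1O` has not yet been measured. It differs from compound 2 by 3-hydroxy-3-methylbut-1-en-1-yl in place of 2-hydroxy-3-methylbut-3-en-1-yl on a saturated chain carbon bound to a double-bonded chain carbon, so the two hold the same atoms arranged differently. Among the compounds with values here, with no measured step between related pairs to lean on, the change is expected to bring no shift beyond the usual scatter, and the step that the limit leaves unreadable from compound 2 to compound 3 is estimated accordingly. Compound 3 is therefore expected to sit near the limit as well, estimated at 15000 nM, within a range from 7000 nM to 40000 nM.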

Compound 3, half-maximal effective concentration: > 10000 nM
Compound 3 ended at the assay's limit (the forecaster's own chance of this, stated with the estimate: 70%); the middle value is on the limit's open side.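

Compound 2 and compound 3 both end at a limit of this assay rather than at a number, so no step can be read between them: the limit of > 10000 nM in this assay, at which 2 of the 3 values shown sit. On these data alone, how far either compound lies past that limit stays open, and so does whether 3-hydroxy-3-methylbut-1-en-1-yl in place of 2-hydroxy-3-methylbut-3-en-1-yl changes the read-out at all.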